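The source may hold more compounds than are shown below. What is called first, only, known or untested is meant among the compounds shown, and "the series" means these compounds.

In an ADME assay on MT4 cells (Homo sapiens) for cytotoxicity, read by MTT assay, with a stated time of 5 days (a higher number here means that more compound is tolerated, a lower number that less compound is tolerated), compound 1 (`CCCCCNc1cc(Oc2c(OC)cc3cc(C#N)ccc3c2OC)nc(Nc2ccc(C#N)cc2)n1`) gives > 125000 nM as a limit, not a number. Compound 2 (`CCCCCC(C)Nc1cc(Oc2c(OC)cc3cc(C#N)ccc3c2OC)nc(Nc2ccc(C#N)cc2)n1`) gives > 125000 nM as a limit too. Compound 3 (`COc1cc2cc(C#N)ccc2c(OC)c1Oc1cc(NCC2CC2)nc(Nc2ccc(C#N)cc2)n1`) also gives > 125000 nM as a limit, so its standing among the others cannot be read. All the measured compounds rest on one reading (the limit of > 125000 nM in this assay, at which 3 of the 3 values shown sit).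

Compound 4 (`COc1cc2cc(C#N)ccc2c(OC)c1Oc1cc(NC2CCCC2)nc(Nc2ccc(C#N)cc2)n1`) differs from compound 3 by cyclopentyl in place of cyclopropylmethyl on a nitrogen on an aromatic ring. Among the compounds with values here, three measured steps bear on this change, all at that same nitrogen: (a step that the two limits leave unreadable from compound 2 to compound 3), (a step that the two limits leave unreadable from compound 1 to compound 3) and (a step that the two limits leave unreadable from compound 1 to compound 2). None of them has a readable size, so they offer no direction, and no step beyond the scatter is expected. The expected step is (a number no higher from compound 3 to compound 4 (the limit leaves the size open)) in either direction. Compound 4 is estimated at 125000 nM in this assay with an expected range of 50000 nM to 250000 nM around it.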

Compound 4, half-maximal cytotoxic concentration: > 125000 nM
Compound 4: only a limit was reported (the forecaster's own chance of this, stated with the estimate: 75%); the middle value sits exactly at the limit.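

In this assay compound 4 gives > 125000 nM, which is a limit. Its steps from compound 1, compound 2 and compound 3 therefore cannot be read. The compounds shown leave open whether the group on the nitrogen changes the tolerated concentration at all: the limit of > 125000 nM in this assay, at which 4 of the 4 values shown sit.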